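Swapping Butoxy for Trifluoromethyl on a Carbonyl Carbon

The source may report more compounds than this note shows. Statements on the series, on what has been measured and on what is new or still open speak of the compounds shown alone.

In a functional assay on K562 cells (Homo sapiens) for antiproliferative activity, read by MTT assay (on this read-out lower numbers stand for stronger inhibition and higher numbers for weaker inhibition), compound 1 `O=C1NC(c2ccccc2)CN1S(=O)(=O)c1ccc2c(c1)CCCN2` gives only a limit, > 20000 nM. Compound 2 `CC(C)COC(=O)N1CCCc2cc(S(=O)(=O)N3CC(c4ccccc4)NC3=O)ccc21` reads 2380 nM and compound 3 `CCCCOC(=O)N1CCCc2cc(S(=O)(=O)N3CC(c4ccccc4)NC3=O)ccc21` reads 3680 nM, so compound 3 stands level with compound 2, within the scatter. Compound 4 `O=C1NC(c2ccccc2)CN1S(=O)(=O)c1ccc2c(c1)CCCN2C(=O)C(F)(F)F` has trifluoromethyl in place of butoxy on a carbonyl carbon. Two measured steps show that a group on that nitrogen matters: an at least 8.4-fold lower number from compound 1 to compound 2 (0.92 log units; beyond the scatter) and an at least 5.4-fold lower number from compound 1 to compound 3 (0.73 log units; beyond the scatter). Changing the chain on the carbonyl carbon moved little, with a 1.5-fold higher number from compound 2 to compound 3 (0.19 log units; within the scatter) staying within the scatter. Compound 4 keeps the carbonyl, so the expected step, a 1.5-fold higher number from compound 3 to compound 4 (0.17 log units; within the scatter), stays within the scatter in this assay, though this swap is larger and less certain. For compound 4 the estimated value is 5500 nM, with an expected range of 1500 nM to 20000 nM.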

Compound 4, half-maximal inhibitory concentration: > 20000 nM
Compound 4: a limit, no number; the forecaster's own chance of this, stated with the estimate: 25%; at least 3.6-fold (0.56 log units) between middle value and limit.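

The carbonyl alone does not carry the gain at this position: in this assay, trifluoromethyl in place of butoxy gives an at least 5.4-fold higher number from compound 3 to compound 4 (0.73 log units; beyond the scatter), and trifluoromethyl in place of isobutoxy gives an at least 8.4-fold higher number from compound 2 to compound 4 (0.92 log units; beyond the scatter). So what sits on the carbonyl carbon counts, which the butoxy and isobutoxy chains alone could not show. Compound 1 and compound 4 cannot be read against each other, because both sit at a limit: the limit of > 20000 nM in this assay, at which 2 of the 4 values shown sit.

As far as these compounds go, whether the oxygen or the chain of butoxy matters stays open. A pentyl chain, a methoxy group or an amine on the carbonyl carbon could separate the two.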